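This account rests on a few compounds, and the source may have more. Where it says the series, first, only, none or still open, it means among the compounds named here.

Measured so far in an ADME assay on the whole organism (Canis lupus familiaris) for pharmacokinetics, at a dose of 10 mg/kg by the oral route; on this read-out lower numbers stand for lower oral bioavailability and higher numbers for higher oral bioavailability:
- compound 1 `Cc1cc(C(F)(F)F)ccc1-c1cc2cnn([C@@H](CC(C)C)c3ccc(C(=O)NCCC(=O)O)cc3)c2cc1C` gives 39.5%
- compound 2 `Cc1cc(C(F)(F)F)ccc1-c1cc2cn([C@@H](CC(C)C)c3ccc(C(=O)NCCC(=O)O)cc3)nc2cc1C` gives 45%

In this assay compound 1 stands at 39.5% and compound 2 at 45%, so the two lie within the scatter of each other.

Compound 3 `Cc1cc2c(cnn2[C@@H](CC(C)C)c2ccc(C(=O)NCCC(=O)O)cc2)cc1-c1ccc(C(F)(F)F)cc1Cl` has not been measured. It differs from compound 1 by chloro in place of methyl on an aromatic carbon, ortho to a large group and meta to a trifluoromethyl group. The 2-methyl-4-(trifluoromethyl)phenyl thus becomes 2-chloro-4-(trifluoromethyl)phenyl.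

Among the compounds with values here, no measured pair shows this change, so the data give no direction for it. No step beyond the scatter is expected. The estimated change is a number 0.5 percentage points higher from compound 1 to compound 3 (within the scatter). For compound 3 the expected value is 40%, within an estimated range from 22% to 58%.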

Compound 3, oral bioavailability: 57.3%
Beside the measured number, compound 3's estimate is 17.3 percentage points below it; the measured number falls inside the stated range.
By their numbers in this assay, from the lowest: compounds 1 and 2 (each within the scatter of the next); then compound 3.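

In this assay, within the data shown here, replacing the 2-methyl-4-(trifluoromethyl)phenyl with 2-chloro-4-(trifluoromethyl)phenyl gives a number 17.8 percentage points higher from compound 1 to compound 3 (beyond the scatter) and provides the first step beyond the scatter. This position, ortho to a large group and meta to a trifluoromethyl group, is therefore sensitive to an exchange of one heavy atom for another, with no hydrogen-bond donor, hydrogen-bond acceptor, ring or net charge entering or leaving. Nothing measured here bears on the reason for this step.

On these data alone, the step rests on a single pair, so it remains open whether the same exchange would carry over to compound 2. Also open, as far as these compounds go, is how fluoro, methoxy or a nitrile at this position would compare with chloro and methyl.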